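A few compounds are considered here, and "the series" means these few. Any claim that something is new, unique, unknown or untested is made for them only; others in the source may bear on it.

Measured compounds:
compound 1 `Nc1ccc(S(=O)(=O)N2CCN(c3ncc(C(O)(C(F)(F)F)C(F)(F)F)cc3C#CC3CC3)CC2)cn1` — 67 mL.min-1.g-1
compound 2 `CCn1cc(-c2cc(C(O)(C(F)(F)F)C(F)(F)F)cnc2N2CCN(S(=O)(=O)c3ccc(N)nc3)CC2)cn1` — 194 mL.min-1.g-1

In an ADME assay (liver) for metabolic stability, with Liver microsome (Rattus norvegicus) as the target, using microsomes and NADPH, with a stated time of 30 min, tested at 1 uM (on this read-out higher numbers stand for fast clearance and lower numbers for slow clearance), compound 1 gives the lower of the two numbers, so it is cleared more slowly than compound 2. Compound 3 `CC(C)(C)n1cc(-c2cc(C(O)(C(F)(F)F)C(F)(F)F)cnc2N2CCN(S(=O)(=O)c3ccc(N)nc3)CC2)cn1` differs from compound 1 by 1-(tert-butyl)-1H-pyrazol-4-yl in place of 2-cyclopropylethynyl on an aromatic carbon. For the measured compounds named here, the one measured step that bears on this change is a 2.9-fold higher number from compound 1 to compound 2 (0.46 log units; beyond the scatter), where a related pyrazole replaced the same alkyne. A step of similar size, or somewhat larger, toward faster clearance is therefore expected here, namely a 3.4-fold higher number from compound 1 to compound 3 (0.54 log units; beyond the scatter). Compound 3 is thus estimated at 230 mL.min-1.g-1, with a likely range from 110 mL.min-1.g-1 to 480 mL.min-1.g-1.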

Compound 3, intrinsic clearance in microsomes: 459 mL.min-1.g-1
Beside the measured number, compound 3's estimate is 2.0-fold (0.30 log units) below it; the measured number falls inside the stated range.
By their numbers in this assay, from the lowest: compound 1; then compound 2; then compound 3.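

In this assay, the group on the pyrazole nitrogen matters: tert-butyl in place of ethyl gives a 2.4-fold higher number from compound 2 to compound 3 (0.37 log units; beyond the scatter), so this position responds to a change made away from the aromatic carbon itself. Swapping 2-cyclopropylethynyl for 1-(tert-butyl)-1H-pyrazol-4-yl gives a 6.9-fold higher number from compound 1 to compound 3 (0.84 log units; beyond the scatter), the largest step among these compounds. No measurement shown explains these rises.

Going by these compounds, whether a methyl group or a hydroxyethyl chain on that nitrogen would lower the number remains open. So does whether any pyrazole here could match compound 1.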